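The source may hold more compounds than are shown below. What is called first, only, known or untested is meant among the compounds shown, and "the series" means these compounds.

Working notes on the series, measured in an ADME assay on Vero cells (Chlorocebus sabaeus) for cytotoxicity, read by MTT assay; a lower number here means a stronger inhibitor, a higher number a weaker inhibitor:

- Compound 1 `CCCC(C)C(=O)OCC(C)(C)CC1=C(O)C(=O)c2ccccc2C1=O`: 120 nM
- Compound 2 `CCCCCCCC(=O)OCC(C)(C)CC1=C(O)C(=O)c2ccccc2C1=O`: > 258000 nM

In this assay compound 2 gives > 258000 nM, which is a limit of the assay and not a number. Within the data shown here, the series so far shows (the limit of > 258000 nM in this assay, at which 1 of the 2 values shown sits).

Compound 3 `CCCCCCCCCC(=O)OCC(C)(C)CC1=C(O)C(=O)c2ccccc2C1=O` differs from compound 2 at one place: ethyl in place of hydrogen on a saturated chain carbon, seven bonds along the chain from a carbonyl carbon. In words, this is ethyl in place of hydrogen on a saturated chain carbon, seven bonds along the chain from a carbonyl carbon.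

Among the measured compounds shown here, one measured step bears on this change: an at least 2100-fold higher number from compound 1 to compound 2 (3.33 log units; beyond the scatter). It is large and involves the same ester chain, but it is a different change, heptyl in place of 1-methylbutyl on a carbonyl carbon. It also ends at a limit, so it gives no size for a further extension of the chain.

The expectation therefore rests on compound 2, with its limit of > 258000 nM. No step beyond the scatter is expected in this assay, in either direction, and a second limit is the likeliest report. The estimate corresponds to an expected a number no higher from compound 2 to compound 3 (the limit leaves the size open). For compound 3 the estimated value is 258000 nM, with an expected range of 40000 nM to 600000 nM.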

Compound 3, half-maximal inhibitory concentration: 203000 nM
The estimate for compound 3 lay 1.3-fold (0.10 log units) above the measured number; measured number inside the range.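

Nonyl in place of 1-methylbutyl now has a measured size in this assay: a 1700-fold higher number from compound 1 to compound 3 (3.23 log units; beyond the scatter), with a number at both ends, where the earlier step on this ester chain ended at a limit. Ethyl in place of hydrogen on a saturated chain carbon, seven bonds along the chain from a carbonyl carbon, gives an at least 1.2-fold lower number from compound 2 to compound 3 (0.10 log units; that floor lies within the scatter), so no change in this assay can be claimed for this extension. Compound 2 remains a limit of the assay and not a number: the limit of > 258000 nM in this assay, at which 1 of the 3 values shown sits.

The compounds shown leave open whether the large gap from compound 1 follows the methyl branch of 1-methylbutyl or the length of the chain, and a pentyl ester would separate the two. Also open, on these data alone, is whether a 1-methylheptyl chain, or an amide in place of the ester, would stay close to compound 1 or move towards compound 3 in this assay.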